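The source may report more compounds than this note shows. Statements on the series, on what has been measured and on what is new or still open speak of the compounds shown alone.

Measured in a functional assay on MCF7 cells (Homo sapiens) for cytotoxicity, read by WST assay, with a stated time of 72 h; on this read-out lower numbers stand for stronger inhibition and higher numbers for weaker inhibition:
- compound 1 `CCCOc1ccc(C2(c3ccc(O)cc3)C(=O)Nc3c2ccc(F)c3F)cc1`: 356 nM
- compound 2 `O=C1Nc2c(ccc(F)c2F)C1(c1ccc(O)cc1)c1cccs1`: 82 nM

Of these two compounds, compound 2 has the lower number, and the gap to compound 1 lies beyond the scatter. The two share a core, but they differ in more than one place, so no single structural step can be read from them.

The next compound is compound 3 `O=C1Nc2c(ccc(F)c2F)C1(CC1CCCCC1)c1ccc(O)cc1`. It has cyclohexylmethyl in place of thiophen-2-yl on a saturated ring carbon, two ring bonds from the ring nitrogen: cyclohexylmethyl in place of thiophen-2-yl on a saturated ring carbon.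

In this assay, a moderate step towards a higher number, beyond the scatter, is expected. The basis for this is thin. Within the data shown here, compound 2, at 82 nM, already holds the lowest number so far, while compound 1, at 356 nM, shows that a higher number occurs with this core. Among the measured compounds shown here, no measured compound carries cyclohexylmethyl. The expected change is an estimated step of a 3.7-fold higher number from compound 2 to compound 3 (0.56 log units; beyond the scatter). For compound 3 the estimated value is 300 nM, with an expected range of 90 nM to 1000 nM.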

Compound 3, half-maximal inhibitory concentration: 102 nM
Compound 3: middle estimate off by 2.9-fold (0.47 log units), on the high side, within the range that was stated.
By their numbers in this assay, from the lowest: compounds 2 and 3 (each within the scatter of the next); then compound 1.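

In this assay, among these compounds, the exchange of thiophen-2-yl for cyclohexylmethyl on a saturated ring carbon, two ring bonds from the ring nitrogen, gives a 1.2-fold higher number from compound 2 to compound 3 (0.09 log units; within the scatter) and is the first single change that can be read at this place. The two groups share little in what can be counted: a five-membered aromatic ring with one hetero atom and one hydrogen-bond acceptor leaves, and a six-membered non-aromatic ring of carbon only, with no hydrogen-bond acceptor, enters, yet this read-out does not separate the two compounds. Nothing available explains this result or links it to a measured property of either group.

The compounds shown leave open how a group of another kind at this place, such as an amine, a carboxylic acid or a longer chain, would read in this assay and whether it would stay within the scatter of compound 2 and compound 3. Among the compounds shown here, with only one step at this position, it also remains open whether a cyclohexyl group joined directly to the ring carbon, without the methyl link, would give a similar number.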